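Ortho substituent swap on the shared core: nitro to chloro

The source may report more compounds than this note shows. Statements on the series, on what has been measured and on what is new or still open speak of the compounds shown alone.

Of the compounds shown here, three of the shared core have been read in an ADME assay on Vero cells (Chlorocebus sabaeus) for cytotoxicity, read by neutral red uptake, tested at 197 ug/mL; a higher number here means a weaker effect of the compound at the concentration tested, a lower number a stronger effect. Compound 1 `O=C1CSC(c2c(Cl)cccc2Cl)N1CCN1CCCCC1` gives 75% in this assay, compound 2 `O=C1CSC(c2ccc([N+](=O)[O-])cc2)N1CCN1CCCCC1` gives 72%, and compound 3 `O=C1CSC(c2ccccc2[N+](=O)[O-])N1CCN1CCCCC1` gives 100%. Compound 3 stands highest of the three: its nearest neighbour is compound 1, lower by a margin beyond the scatter, and compound 2 lies further below, also beyond the scatter.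

Compound 4 `O=C1CSC(c2ccccc2Cl)N1CCN1CCCCC1` differs from compound 3 in one place: chloro in place of nitro on an aromatic carbon. Among the compounds with values here, no pair with this change has been measured. A downward step is expected, because compound 1 carrying chloro groups gives 75% in this assay. The expected step from compound 3 to compound 4 is a number 15 percentage points lower from compound 3 to compound 4 (beyond the scatter). Compound 4 is estimated at 85%, between 62% and 100%.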

Compound 4, a percentage reported as activity, at one concentration (the size of the read-out at that concentration, not a potency): 71%
Estimate against measurement, compound 4: 14 percentage points above, within the range that was stated.
By their numbers in this assay, from the lowest: compounds 4, 2 and 1 (each within the scatter of the next); then compound 3.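

Chloro in place of nitro on an aromatic carbon ortho to a large group gives a number 29 percentage points lower from compound 3 to compound 4 (beyond the scatter) in this assay, so the reading of compound 3 does not carry over to chloro at this place. Hydrogen in place of chloro on an aromatic carbon gives a number 4 percentage points lower from compound 1 to compound 4 (within the scatter), so a second chloro makes no difference that can be told from the scatter. Nothing at hand explains either step. 

On these data alone, whether an amine or a methoxy group at this place would read like nitro or like chloro remains open. So does whether the nitro reading holds with a longer chain to the piperidine-bearing end of the shared core.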